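This account rests on a few compounds, and the source may have more. Where it says the series, first, only, none or still open, it means among the compounds named here.

Three compounds have numbers in a functional assay for inhibition, with Homo sapiens as the target; a higher number here means a weaker inhibitor, a lower number a stronger inhibitor. Compound 1 `c1cc(Nc2nccc(-c3ccncc3)n2)cc(OCCn2ccnc2)c1` gives 200 nM, compound 2 `Cc1cccc(Nc2nccc(-c3cc(C)oc3C)n2)c1` gives 28500 nM, and compound 3 `Cc1cccc(Nc2nccc(-c3ccsc3)n2)c1` gives 3800 nM. Compound 3 therefore holds the second highest of the three numbers: its nearest neighbour is compound 2, higher by a margin beyond the scatter, and its furthest is compound 1, lower by a margin beyond the scatter. Going by the values given here, the only measured step that exchanges the ring at this position is a 7.5-fold lower number from compound 2 to compound 3 (0.88 log units; beyond the scatter), a modest step. Compound 4 `Cc1cccc(Nc2nccc(-c3ccncc3)n2)c1` differs from compound 3 by pyridin-4-yl in place of thiophen-3-yl on an aromatic carbon. Among the compounds with values here, no measured step exchanges thiophen-3-yl for pyridin-4-yl on the shared core, but compound 1 carries pyridin-4-yl at the same position and shows the lowest number of the three, so the aryl exchange is expected to lower the number again, in the same direction as the step from compound 2 to compound 3. The expected step in this assay is a 4.8-fold lower number from compound 3 to compound 4 (0.68 log units; beyond the scatter). Compound 4 is accordingly estimated at 800 nM, with a range from 200 nM to 3000 nM.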

Compound 4, half-maximal inhibitory concentration: 8800 nM
The estimate for compound 4 lay 11-fold (1.04 log units) below the measured number; measured number above the stated range.
By their numbers in this assay, from the lowest: compound 1; then compound 3; then compound 4; then compound 2.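

In this assay, pyridin-4-yl does not improve on thiophen-3-yl on the shared core: the exchange gives a 2.3-fold higher number from compound 3 to compound 4 (0.36 log units; beyond the scatter), while the exchange for 2,5-dimethylfuran-3-yl gives a 3.2-fold lower number from compound 2 to compound 4 (0.51 log units; beyond the scatter), placing the pyridin-4-yl compound between the other two. With pyridin-4-yl held constant, methyl in place of 2-(1H-imidazol-1-yl)ethoxy gives a 44-fold higher number from compound 1 to compound 4 (1.64 log units; beyond the scatter), the largest step shown, so the low number of compound 1 goes with that side chain and not with pyridin-4-yl alone. No evidence is available to explain these differences.

The compounds shown leave open whether thiophen-3-yl would keep its edge over pyridin-4-yl alongside 2-(1H-imidazol-1-yl)ethoxy. They also leave open how a phenyl ring at this position, or a chain ending in an amine in place of methyl, would read.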